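The compounds below may be only part of what the source reports. "The series", "measured", "known", "first", "only" and "open" are said of these compounds alone.

Compound 1 `O=C(N/N=C/c1cccc([N+](=O)[O-])c1)N1CCc2ncnc(Nc3ccc(F)c(Cl)c3)c2C1`: in a functional assay on MKN-45 cells (Homo sapiens) for cytotoxicity, read by MTT assay, with a stated time of 72 h (a lower number here means a stronger inhibitor, a higher number a weaker inhibitor), compound 1 reaches only a limit of the assay, > 200000 nM.
Compound 2 `O=C(N/N=C/c1ccc(F)cc1)N1CCc2ncnc(Nc3ccc(F)c(Cl)c3)c2C1`: in this assay compound 2 gives 10900 nM.

Within the data shown here, compound 2 holds the only real number among the two measured compounds; the other value is a limit, as the limit of > 200000 nM in this assay, at which 1 of the 2 values shown sits, records for compound 1. Among the measured compounds shown here, the single measured step, an at least 18-fold lower number from compound 1 to compound 2 (1.26 log units; beyond the scatter), concerns the same position, a carbon with a double bond to nitrogen, where the change for compound 3 `O=C(N/N=C/c1cccs1)N1CCc2ncnc(Nc3ccc(F)c(Cl)c3)c2C1` also sits: thiophen-2-yl in place of 4-fluorophenyl on a carbon with a double bond to nitrogen. For the measured compounds named here, that earlier step is large, but it starts from a limit and involves a different pair of groups; it shows only that exchange at this position can move the number strongly. The exchange of 4-fluorophenyl for thiophen-2-yl is expected to move the number less, and the step of a 1.4-fold higher number from compound 2 to compound 3 (0.14 log units; within the scatter) is expected to stay within or just beyond the scatter. Compound 3 is therefore estimated at 15000 nM, in the range 4000 nM to 60000 nM.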

Compound 3, half-maximal inhibitory concentration: 57300 nM
Beside the measured number, compound 3's estimate is 3.8-fold (0.58 log units) below it, and the stated range covers the measured number.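

In this assay, the exchange of 4-fluorophenyl for thiophen-2-yl gives a 5.3-fold higher number from compound 2 to compound 3 (0.72 log units; beyond the scatter), so this place on a carbon with a double bond to nitrogen responds even to a swap between two rings that carry no nitro group. Thiophen-2-yl also separates from 3-nitrophenyl, with an at least 3.4-fold lower number from compound 1 to compound 3 (0.54 log units; beyond the scatter), and compound 2 now holds the lowest number of the three, its steps to both others lying beyond the scatter. The second of those steps rests on compound 1, whose value is a limit of the assay: the limit of > 200000 nM in this assay, at which 1 of the 3 values shown sits.

From the compounds shown here alone, what a plain phenyl, a furan-2-yl or a saturated cyclohexyl group would give at this place stays open. So does whether the fluorine or the six-membered ring goes with the lower number of compound 2.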